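A few compounds are considered here, and "the series" means these few. Any claim that something is new, unique, unknown or untested is made for them only; others in the source may bear on it.

Series notes. Among the measured compounds shown here, in a functional assay on HT-29 cells (Homo sapiens) for cytotoxicity, read by MTT assay, with a stated time of 72 h (on this read-out lower numbers stand for stronger inhibition of growth and higher numbers for weaker inhibition of growth), compound 1 `C=CCOC(=O)Nc1ccc([Se]C#N)cc1` gives 24500 nM, the second highest of the three numbers so far. Compound 3 `CCCCOC(=O)Nc1ccc([Se][Se]c2ccc(NC(=O)OCCCC)cc2)cc1` gives 27600 nM in this assay, and compound 2 `O=C(Nc1ccc([Se][Se]c2ccc(NC(=O)OCc3ccc([N+](=O)[O-])cc3)cc2)cc1)OCc1ccc([N+](=O)[O-])cc1` gives 16700 nM in this assay; both differences from compound 1 fall within the usual scatter, so no order among the three is claimed. Compound 4 `CCCCOC(=O)Nc1ccc([Se]C#N)cc1` has not been measured. It differs from compound 1 by propyl in place of vinyl on a saturated chain carbon bound to an oxygen next to a carbonyl group. Among the measured compounds, the only variation at the carbamate ester, compound 2 against compound 3, shows two values within the scatter of each other. On that basis a 1.0-fold higher number from compound 1 to compound 4 (0.01 log units; within the scatter) is expected in this assay, not beyond the scatter and in no set direction. Compound 4 is accordingly expected to give 25000 nM in this assay, with a range from 10000 nM to 60000 nM.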

Compound 4, concentration for 50% growth inhibition: 8100 nM
Estimate against measurement, compound 4: 3.1-fold (0.49 log units) above, outside the stated range (below it).
By their numbers in this assay, from the lowest: compound 4; then compounds 2, 1 and 3 (each within the scatter of the next).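

In this assay, among the compounds shown here, allyl to butyl at this position gives a 3.0-fold lower number from compound 1 to compound 4 (0.48 log units; beyond the scatter), the first step that lies beyond the scatter, so the chain on the carbamate oxygen can change the number in this assay. The step both lengthens the chain and removes its double bond, and the compounds shown do not separate the two. Nothing measured here bears on the reason for this step. From the compounds shown here alone, whether a saturated propyl chain would behave like allyl or like butyl stays open. So does the effect of a longer chain, such as hexyl, or of an amine at the chain end.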